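Swapping Trifluoromethyl for Trifluoromethoxy on a Glucagon Ligand

A few compounds are considered here, and "the series" means these few. Any claim that something is new, unique, unknown or untested is made for them only; others in the source may bear on it.

Compound 1 `O=C(O)CCNC(=O)c1ccc(CN(c2ccc(Cl)cc2)c2nc(-c3ccc(C(F)(F)F)cc3)cs2)cc1` was tested in an assay on membranes from liver for binding affinity to Glucagon receptor (Rattus norvegicus) (on this read-out higher numbers stand for weaker inhibition and lower numbers for stronger inhibition), where compound 1 gives 1400 nM. Among the three compounds measured, compound 1 carries the lowest number. Compound 3 `O=C(O)CCNC(=O)c1ccc(CN(c2ccc(OC(F)(F)F)cc2)c2nc(-c3ccc(C(F)(F)F)cc3)cs2)cc1` gives 2000 nM, and a 1.4-fold higher number from compound 1 to compound 3 (0.15 log units; within the scatter). Compound 2 `O=C(O)CCNC(=O)c1ccc(CN(c2ccc3c(c2)CCC3)c2nc(-c3ccc(C(F)(F)F)cc3)cs2)cc1` gives 5400 nM; here a 3.9-fold higher number from compound 1 to compound 2 (0.59 log units; beyond the scatter), while a 2.7-fold lower number from compound 2 to compound 3 (0.43 log units; beyond the scatter). Compound 4 `O=C(O)CCNC(=O)c1ccc(CN(c2ccc(Cl)cc2)c2nc(-c3ccc(OC(F)(F)F)cc3)cs2)cc1` has not yet been measured. It differs from compound 1 in one place: trifluoromethoxy in place of trifluoromethyl on an aromatic carbon. Among the measured compounds shown here, none of the measured steps touches this position; all three alter the group attached to the nitrogen instead. The nearest comparison is the step from compound 1 to compound 3, where trifluoromethoxy took the place of chloro on an aromatic carbon and the number stayed within the scatter. Because a 1.4-fold higher number from compound 1 to compound 3 (0.15 log units; within the scatter) was small, the change in compound 4 is expected to give a step of a 1.2-fold higher number from compound 1 to compound 4 (0.08 log units; within the scatter), with no clear direction. Compound 4 is therefore estimated at 1700 nM, within a range from 700 nM to 4500 nM.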

Compound 4, half-maximal inhibitory concentration: 1700 nM
Estimate against measurement, compound 4: no gap at the digits printed, and the stated range covers the measured number.
By their numbers in this assay, from the lowest: compounds 1, 4 and 3 (each within the scatter of the next); then compound 2.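

Among the compounds shown here, this is the first measured step at the 4-(trifluoromethyl)phenyl end of the molecule, since all the earlier steps changed the group on the nitrogen. In this assay, putting trifluoromethoxy in place of trifluoromethyl on this aromatic carbon, para to a large group, gives a 1.2-fold higher number from compound 1 to compound 4 (0.08 log units; within the scatter), so the extra oxygen, which adds one hydrogen-bond acceptor, brings no difference that can be told from the scatter. Nothing measured here offers an explanation for this result.

The compounds shown leave open whether this position would respond to a very different group, such as an amine, a carboxylic acid or a longer carbon chain. They also leave open whether the same swap would read alike with the 2,3-dihydro-1H-inden-5-yl group of compound 2 on the nitrogen.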